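Swapping the chlorophenyl cap for cyclohexyl on compound 2

The source may hold more compounds than are shown below. What is called first, only, known or untested is meant among the compounds shown, and "the series" means these compounds.

Of the compounds shown here, three sharing one core have been measured in an assay on isolated protein for inhibition of protein deacetylase HDAC6 (Homo sapiens), read by fluorescence, with stated times of 5 min and 60 min; on this read-out higher numbers stand for weaker inhibition and lower numbers for stronger inhibition. Compound 1 `O=C(CCC1C(=O)N(c2ccc(Cl)cc2)C(=O)N1Cc1ccccc1)Nc1ccc(C(=O)NO)cc1` gives 7.6 nM. Compound 2 `CCCN1C(=O)N(c2ccc(Cl)cc2)C(=O)C1CCC(=O)Nc1ccc(C(=O)NO)cc1` gives 12.6 nM, and compound 3 `CN1C(=O)N(c2ccc(Cl)cc2)C(=O)C1CCC(=O)Nc1ccc(C(=O)NO)cc1` gives 7 nM. Compound 2 has the highest of the three numbers, yet its nearest neighbour is compound 1 and the step of a 1.7-fold higher number from compound 1 to compound 2 (0.22 log units; within the scatter) lies within the scatter, as does the step of a 1.8-fold lower number from compound 2 to compound 3 (0.26 log units; within the scatter), so the three cannot be ranked against one another.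

Compound 4 `CCCN1C(=O)N(C2CCCCC2)C(=O)C1CCC(=O)Nc1ccc(C(=O)NO)cc1` is not yet measured. It differs from compound 2 in one place: cyclohexyl in place of 4-chlorophenyl on an amide-type nitrogen in a ring. Every measured step concerns the other ring position, the saturated chain carbon bound to the amide-type nitrogen: a 1.7-fold higher number from compound 1 to compound 2 (0.22 log units; within the scatter), a 1.1-fold lower number from compound 1 to compound 3 (0.04 log units; within the scatter) and a 1.8-fold lower number from compound 2 to compound 3 (0.26 log units; within the scatter) were all within the scatter. Among the compounds with values here, none of them touches the group on the ring nitrogen, so there is no direct precedent for the change to compound 4. The hydroxamic acid end of the molecule is unchanged, which argues against a large shift, but the new group is an untested one, so the estimate is kept broad. Compound 4 is expected to show a step of a 1.4-fold higher number from compound 2 to compound 4 (0.15 log units; within the scatter), with an estimated value of 18 nM in this assay, between 6 nM and 55 nM.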

Compound 4, half-maximal inhibitory concentration: > 40 nM
Compound 4: a limit, no number; the forecaster's own chance of this, stated with the estimate: 2%; middle value at least 2.2-fold (0.34 log units) away from the limit.
By their numbers in this assay, from the lowest: compounds 3, 1 and 2 (each within the scatter of the next). At a limit, above all of these: compound 4.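

With cyclohexyl in place of 4-chlorophenyl on the amide-type nitrogen in a ring, the series gains its first step beyond the scatter, an at least 3.1-fold higher number from compound 2 to compound 4 (0.50 log units; beyond the scatter), whereas every step at the saturated chain carbon stayed within it. This single exchange therefore gives weaker inhibition, so the group on this ring nitrogen is not interchangeable in the way the groups compared at the chain carbon were, at least for this one pair. Compound 4 gives a limit and not a number in this assay: the limit of > 40 nM in this assay, at which 1 of the 4 values shown sits.

The exchange removes the chlorine and replaces the six-membered aromatic ring with a non-aromatic one in the same step, and the compounds shown cannot separate these two changes; a plain phenyl group on this nitrogen would show what the chlorine alone contributes, while a cyclohexylmethyl group or a piperidine ring would test other non-aromatic options. Going by these compounds, it also remains open whether cyclohexyl has the same effect alongside the other groups, such as the benzyl of compound 1 or the methyl of compound 3.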